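This account rests on a few compounds, and the source may have more. Where it says the series, first, only, none or still open, it means among the compounds named here.

The measured compounds, in an assay on membranes from HEK293 cells for displacement of a labelled ligand from adenosine receptor A2b (Homo sapiens), read by scintillation counting, with a stated time of 30 min, tested at 1 uM; a lower number here means less inhibition, a higher number more inhibition at the concentration tested (going by the name of the read-out):
compound 1, `CC1=C(C(=O)OC(C)(C)C)C(c2cccs2)NC(=S)N1`, gives 26%;
compound 2, `CC1=C(C(=O)OCc2ccccc2)C(c2cccs2)NC(=S)N1`, gives 45%;
compound 3, `CC1=C(C(=O)OC(C)(C)C)C(c2ccsc2)NC(=S)N1`, gives 26%.

Compound 1 and compound 2 share one core and differ at a single place: benzyl in place of tert-butyl on an oxygen next to a carbonyl group. That change made a step of a number 19 percentage points higher from compound 1 to compound 2 (beyond the scatter). Compound 3 carries a different core than compound 1: thiophen-3-yl in place of thiophen-2-yl on a saturated ring carbon. The read-out moved no change at the digits printed from compound 1 to compound 3 (within the scatter), so compound 3 and compound 1 stand together as the lowest pair of the three.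

Compound 4, `CC1=C(C(=O)OCc2ccccc2)C(c2ccsc2)NC(=S)N1`, is not yet measured. It stands to compound 3 as compound 2 stands to compound 1: benzyl in place of tert-butyl on an oxygen next to a carbonyl group. From the compounds shown here alone, both changes sit at the same place, described in the same words, so this is the same change, seen in both pairs, once measured and once still open.

Because the measured step of a number 19 percentage points higher from compound 1 to compound 2 (beyond the scatter) was modest but beyond the scatter, and because compound 3 started level with compound 1 no change at the digits printed from compound 1 to compound 3 (within the scatter), compound 4 is expected to show a step of about a number 19 percentage points higher from compound 3 to compound 4 (beyond the scatter). Compound 4 is therefore estimated at 45%, most likely between 30% and 60%.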

Compound 4, a percentage reported as inhibition, at one concentration (the size of the read-out at that concentration, not a potency): 10%
The estimate for compound 4 lay 35 percentage points above the measured number; the whole stated range lies above it.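

In this assay, benzyl in place of tert-butyl on the oxygen gave a number 16 percentage points lower from compound 3 to compound 4 (beyond the scatter), so on this core the change ran the opposite way to the step seen on the core of compound 1: the same change on two cores in this assay, a number 19 percentage points higher (beyond the scatter) from compound 1 to compound 2 and a number 16 percentage points lower (beyond the scatter) from compound 3 to compound 4, 35 percentage points apart, beyond the scatter of two such steps. The swap of thiophen-2-yl for thiophen-3-yl also depended on its surroundings, giving a number 35 percentage points lower from compound 2 to compound 4 (beyond the scatter) with benzyl on the oxygen, although it left the number unmoved with tert-butyl: the same change on two cores in this assay, no change at the digits printed (within the scatter) from compound 1 to compound 3 and a number 35 percentage points lower (beyond the scatter) from compound 2 to compound 4, 35 percentage points apart, beyond the scatter of two such steps. In these four compounds, then, the effect of either change cannot be carried over from one core to the other, but the numbers do not show why the two places depend on each other, nor whether this holds beyond these compounds.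

The compounds shown leave open how a longer chain such as n-hexyl on the same oxygen would behave with either thiophene. They also leave open whether an amine on the saturated ring carbon, in place of the thiophene, would respond to benzyl and tert-butyl in either of these ways.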